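Nitro in Place of Bromo on the Aryl Substituent

A few compounds are considered here, and "the series" means these few. Any claim that something is new, unique, unknown or untested is made for them only; others in the source may bear on it.

Of the compounds shown here, three sharing one core have been measured in a functional assay on CHO cells for agonist activity at adenosine receptor A1 (Homo sapiens), read by fluorescence and ERK phosphorylation, with stated times of 30 min and 1.5 h, tested at 10 uM; a higher number here means a stronger effect of the compound at the concentration tested, a lower number a weaker effect. Compound 1 `Nc1scc(-c2ccc(F)cc2)c1C(=O)c1ccccc1` gives 60%, compound 2 `Nc1scc(-c2ccc(Cl)cc2)c1C(=O)c1ccccc1` gives 51%, and compound 3 `Nc1scc(-c2ccc(Br)cc2)c1C(=O)c1ccccc1` gives 49%. Of the steps between them, a number 9 percentage points lower from compound 1 to compound 2 (within the scatter) and a number 2 percentage points lower from compound 2 to compound 3 (within the scatter) stay within the scatter, whereas a number 11 percentage points lower from compound 1 to compound 3 (beyond the scatter) reaches beyond it. Compound 3 thus holds the lowest of the three numbers, with compound 2 nearest and compound 1 furthest from it.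

The next compound is compound 4 `Nc1scc(-c2ccc([N+](=O)[O-])cc2)c1C(=O)c1ccccc1`. The change from compound 3 is counted as nitro in place of bromo on an aromatic carbon. Among the measured compounds shown here, no measured step exchanges a halogen for a nitro group, so none bears directly on this change; the three halogen swaps at this position are the only guide, and they produced at most a modest movement. On that basis only a small shift is expected, if any, with the direction left open and a slight lowering somewhat more likely given the drift already seen across compounds 1 to 3. Compound 4 is therefore estimated to give 45%, with a range from 25% to 65%. This estimate means an expected step of a number 4 percentage points lower from compound 3 to compound 4 (within the scatter), which would remain within the scatter.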

Compound 4, a percentage reported as activity, at one concentration (the size of the read-out at that concentration, not a potency): 47%
The estimate for compound 4 lay 2 percentage points below the measured number; the measured number falls inside the stated range.
By their numbers in this assay, from the lowest: compounds 4, 3, 2 and 1 (each within the scatter of the next, the first and the last beyond it).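

Until now this position had carried only halogens in this assay, and compound 4 shows that it can also hold a nitro group, with three heavy atoms and two hydrogen-bond acceptors, without a clear move in the read-out. Against the heavier halogens the swap gives a number 2 percentage points lower from compound 3 to compound 4 (within the scatter) and a number 4 percentage points lower from compound 2 to compound 4 (within the scatter) so neither bromo nor chloro can be told apart from nitro here. Only the comparison with the fluoro compound, a number 13 percentage points lower from compound 1 to compound 4 (beyond the scatter) is a step of any size, and it is modest and close to a number 11 percentage points lower from compound 1 to compound 3 (beyond the scatter) so at this position, para to a large group, the nitro compound sits with compound 3 rather than opening new ground.

As far as these compounds go, whether an amine, a carboxylic acid or a longer chain in the same place would leave this narrow band remains open, as does whether these similar effects at a single concentration would stay similar at other concentrations. Nothing available here accounts for why these four groups give such close numbers.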